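From Isopropyl to Methylsulfanyl on a Shared Core

The source may hold more compounds than are shown below. What is called first, only, known or untested is meant among the compounds shown, and "the series" means these compounds.

In a functional assay on HCT-116 cells (Homo sapiens) for cytotoxicity, read by MTT assay, with a stated time of 48 h (on this read-out lower numbers stand for stronger inhibition of growth and higher numbers for weaker inhibition of growth), compound 1 `Cc1nc2cc(Cl)c(Cl)cc2n1C1CCCC1` gives 13000 nM, compound 2 `CCc1nc2cc(Cl)c(Cl)cc2n1C1CCCC1` gives 38000 nM and compound 3 `CC(C)c1nc2cc(Cl)c(Cl)cc2n1C1CCCC1` gives 9000 nM. All three share one core and differ only in the group on an aromatic carbon between two ring nitrogen atoms. Two compounds hold the low end of these numbers, with a 1.4-fold lower number from compound 1 to compound 3 (0.16 log units; within the scatter). The high end is reached only through a 2.9-fold higher number from compound 1 to compound 2 (0.47 log units; beyond the scatter), and a 4.2-fold lower number from compound 2 to compound 3 (0.63 log units; beyond the scatter) comes back down. In compound 4 `CSc1nc2cc(Cl)c(Cl)cc2n1C1CCCC1`, not yet measured, methylsulfanyl stands in place of isopropyl: methylsulfanyl in place of isopropyl on an aromatic carbon. Within the data shown here, no measured step involves a group containing sulfur, so these three steps are the only guide. They run in both directions, and the numbers do not move steadily from compound 1 through compound 2 to compound 3. Their modest size suggests a small change, with a slight lean towards a higher number. The expected change is a 1.6-fold higher number from compound 3 to compound 4 (0.19 log units; within the scatter), which means no step beyond the scatter is expected. For compound 4 the estimated value is 14000 nM, with an expected range of 6000 nM to 35000 nM.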

Compound 4, concentration for 50% growth inhibition: 2900 nM
The estimate for compound 4 lay 4.8-fold (0.68 log units) above the measured number, and the stated range ends above it.
By their numbers in this assay, from the lowest: compound 4; then compounds 3 and 1 (each within the scatter of the next); then compound 2.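

In this assay, among these compounds, methylsulfanyl is the only group at this position whose compound stands clear of all the others, with a 3.1-fold lower number from compound 3 to compound 4 (0.49 log units; beyond the scatter) and a 4.5-fold lower number from compound 1 to compound 4 (0.65 log units; beyond the scatter) and a 13-fold lower number from compound 2 to compound 4 (1.12 log units; beyond the scatter) all running the same way. Compound 4 therefore gives the strongest inhibition of growth among these four compounds, whereas compounds 1 and 3 could not be separated from each other. This shows that the numbers at this position can fall further than methyl, ethyl and isopropyl took them, and that the change need not add heavy atoms: methylsulfanyl has fewer than isopropyl.

Going by these compounds, with a single sulfur-containing group, it remains open whether ethylsulfanyl, methoxy or an amine here would lower the number as well. Nothing available explains the fall seen with methylsulfanyl.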